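The compounds below may be only part of what the source reports. "The series", "measured", "known", "first", "only" and "open" are said of these compounds alone.

Working notes on the series, measured so far:
- compound 1 `c1ccc(N2N=C(c3ccc4c(c3)OCCO4)CC2c2ccc3ccccc3c2)cc1`: 13900 nM
- compound 2 `Clc1ccc(C2CC(c3ccc4c(c3)OCCO4)=NN2c2ccccc2)cc1`: 38600 nM

In a functional assay on WM 266-4 cells (Homo sapiens) for antiproliferative activity, read by MTT assay, with a stated time of 24 h (on this read-out lower numbers stand for stronger inhibition of growth and higher numbers for weaker inhibition of growth), compound 2, at 38600 nM, gives the higher of the two numbers. Compound 3 `COc1ccc(C2CC(c3ccc4c(c3)OCCO4)=NN2c2ccccc2)cc1` differs from it by methoxy in place of chloro on an aromatic carbon. Among the measured compounds shown here, one measured step bears on this only indirectly: a 2.8-fold higher number from compound 1 to compound 2 (0.44 log units; beyond the scatter), a modest change that replaces naphthalen-2-yl with 4-chlorophenyl. For the measured compounds named here, no measured step exchanges chloro for methoxy, and the smaller change here is expected to stay within the scatter. The expected step is a 1.3-fold lower number from compound 2 to compound 3 (0.11 log units; within the scatter). For compound 3 the estimate is 30000 nM, with an expected range of 12000 nM to 70000 nM.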

Compound 3, concentration for 50% growth inhibition: > 100000 nM
Compound 3: no number, only a limit (the forecaster's own chance of this, stated with the estimate: 5%); at least 3.3-fold (0.52 log units) between middle value and limit.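

In this assay, compound 3 gives no number, only a limit of the assay: the limit of > 100000 nM in this assay, at which 1 of the 3 values shown sits. On this aromatic carbon, para to a large group, methoxy in place of chloro gives an at least 2.5-fold higher number from compound 2 to compound 3 (0.41 log units; beyond the scatter), so the group at this position matters and not only the ring that carries it. Replacing naphthalen-2-yl with 4-methoxyphenyl gives an at least 7.1-fold higher number from compound 1 to compound 3 (0.85 log units; beyond the scatter), leaving compound 1 with the lowest number of the three.

Going by these compounds, how far compound 3 lies past its limit stays open. So does whether an amine or a carboxylic acid on that aromatic carbon would track compound 2 or compound 3.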